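The source may hold more compounds than are shown below. What is called first, only, known or untested is meant among the compounds shown, and "the series" means these compounds.

In a functional assay on MCF7 cells (Homo sapiens) for antiproliferative activity, read by MTT assay, with a stated time of 24 h (on this read-out higher numbers stand for weaker inhibition and lower numbers for stronger inhibition), compound 1 (`O=S(=O)(c1ccccc1)n1c(-c2cn(-c3ccccc3)nc2-c2ccc(F)cc2)nc2ccccc21`) gives 690 nM and compound 2 (`O=S(=O)(c1ccc(F)cc1)n1c(-c2cn(-c3ccccc3)nc2-c2ccc(F)cc2)nc2ccccc21`) gives 3670 nM, the higher of the two numbers. Compound 3 (`O=S(=O)(c1ccc(C(F)(F)F)cc1)n1c(-c2cn(-c3ccccc3)nc2-c2ccc(F)cc2)nc2ccccc21`) keeps the core of compound 2 but has trifluoromethyl in place of fluoro on an aromatic carbon, para to a large group (trifluoromethyl in place of fluoro on an aromatic carbon). Among the compounds with values here, one measured step bears on this change, at the same place on that ring: fluoro in place of hydrogen gave a 5.3-fold higher number from compound 1 to compound 2 (0.73 log units; beyond the scatter), a modest step beyond the scatter. That step starts from hydrogen rather than fluoro, so it does not fix a direction for the new change. In this assay compound 3 is therefore expected to stay near compound 2 , with no step beyond the scatter expected. The estimated step is a 1.2-fold lower number from compound 2 to compound 3 (0.09 log units; within the scatter) in this read-out. Compound 3 is estimated at 3000 nM, with an expected range from 900 nM to 10000 nM in this read-out.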

Compound 3, half-maximal inhibitory concentration: 1580 nM
Estimate against measurement, compound 3: 1.9-fold (0.28 log units) above; the range from low to high includes it.
By their numbers in this assay, from the lowest: compound 1; then compound 3; then compound 2.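

In this assay, replacing fluoro with trifluoromethyl at this position gives a 2.3-fold lower number from compound 2 to compound 3 (0.37 log units; beyond the scatter), so the read-out here responds to a change between two substituents and not only to the loss of hydrogen. Placing trifluoromethyl where compound 1 has hydrogen gives a 2.3-fold higher number from compound 1 to compound 3 (0.36 log units; beyond the scatter), which means that both substituents shown leave the number higher than hydrogen does, though not to the same degree. Nothing measured here accounts for this order of hydrogen, trifluoromethyl and fluoro.

From the compounds shown here alone, whether an amine, a methoxy group or a carboxylic acid at this position would read nearer to hydrogen or to fluoro remains open. So does whether trifluoromethyl would act in the same way elsewhere on the core of compound 1.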